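Bromo for chloro: a step expected within the scatter

This account rests on a few compounds, and the source may have more. Where it says the series, first, only, none or still open, it means among the compounds named here.

Among the compounds with values here, in a functional assay on NCI-H460 cells (Homo sapiens) for inhibition, read by MTT assay, with a stated time of 24 h, tested at 0.1 ug/mL (on this read-out lower numbers stand for less inhibition of growth and higher numbers for more inhibition of growth at the one concentration tested), compound 1 (`O=C(CCCCC1CCSS1)Nc1ccccn1`) gives 2.61%, and compound 2 (`O=C(CCCCC1CCSS1)Nc1ccc(Cl)cn1`) gives 3.93%, so compound 2 stands within the scatter of its only measured neighbour. Compound 3 (`O=C(CCCCC1CCSS1)Nc1ccc(Br)cn1`) differs from compound 2 by bromo in place of chloro on an aromatic carbon. Within the data shown here, the only measured step bearing on this is a number 1.3 percentage points higher from compound 1 to compound 2 (within the scatter), with chloro in place of hydrogen on an aromatic carbon, so no step beyond the scatter is expected in this assay. The estimated change is a number 0.6 percentage points higher from compound 2 to compound 3 (within the scatter). Compound 3 is expected at 4.5%, within an estimated range of -2% to 13%.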

Compound 3, percent growth inhibition at one concentration: 9%
Compound 3: middle estimate off by 4.5 percentage points, on the low side, and the stated range covers the measured number.
By their numbers in this assay, from the lowest: compounds 1, 2 and 3 (each within the scatter of the next).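

In this assay, bromo in place of chloro, on the aromatic carbon two atoms from the ring nitrogen and para to a large group, gives a number 5.1 percentage points higher from compound 2 to compound 3 (within the scatter), and bromo in place of hydrogen gives a number 6.4 percentage points higher from compound 1 to compound 3 (within the scatter). Hydrogen, chloro and bromo at this place are thus not told apart by this read-out at the one concentration tested. No measured evidence speaks to the reason for these steps. As far as these compounds go, whether an amine, a carboxylic acid or a methoxy group at this place would give a step beyond the scatter stays open. So does the effect of a longer chain on the amide carbonyl side.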